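The source may report more compounds than this note shows. Statements on the series, on what has been measured and on what is new or still open speak of the compounds shown alone.

Measured in a functional assay on MGC-803 cells (Homo sapiens) for inhibition, read by MTT assay, with a stated time of 72 h; on this read-out higher numbers stand for weaker inhibition and lower numbers for stronger inhibition:
compound 1 `C#CCSc1nc(Nc2ccccc2)c2ccncc2n1`: 16200 nM
compound 2 `C#CCSc1nc(Nc2ccc(C)cc2)c2ccncc2n1`: 8090 nM
compound 3 `C#CCSc1nc(Nc2ccc(Cl)cc2)c2ccncc2n1`: 16400 nM

Compound 3 gives the highest of the three numbers, but its gap to compound 1 lies within the scatter; only compound 2 sits apart from it, with a 2.0-fold higher number from compound 2 to compound 3 (0.31 log units; beyond the scatter). Compound 4 `C#CCSc1nc(Nc2ccc([N+](=O)[O-])cc2)c2ccncc2n1` differs from compound 3 by nitro in place of chloro on an aromatic carbon. The steps seen so far at this position are a 1.0-fold higher number from compound 1 to compound 3 (0.01 log units; within the scatter) and a 2.0-fold higher number from compound 2 to compound 3 (0.31 log units; beyond the scatter), both small. Nothing measured here points to a larger swing from a nitro group, so no step beyond the scatter is expected in this assay; the estimated step is a 1.0-fold lower number from compound 3 to compound 4 (0.01 log units; within the scatter). Compound 4 is therefore expected at 16000 nM, within 6000 nM to 45000 nM.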

Compound 4, half-maximal inhibitory concentration: > 80000 nM
Compound 4: only a limit was reported; the forecaster's own chance of this, stated with the estimate: 10%; middle value at least 5.0-fold (0.69 log units) away from the limit.
By their numbers in this assay, from the lowest: compounds 2, 1 and 3 (each within the scatter of the next, the first and the last beyond it). At a limit, above all of these: compound 4.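

In this assay, compound 4 is reported only as a limit, not a number: the limit of > 80000 nM in this assay, at which 1 of the 4 values shown sits. Even so, this position is less tolerant than the earlier compounds showed, with nitro in place of chloro giving an at least 4.8-fold higher number from compound 3 to compound 4 (0.68 log units; beyond the scatter), nitro in place of hydrogen giving an at least 4.9-fold higher number from compound 1 to compound 4 (0.69 log units; beyond the scatter), and nitro in place of methyl giving an at least 9.8-fold higher number from compound 2 to compound 4 (0.99 log units; beyond the scatter). Among the substituents shown, only nitro moves the number this far.

As far as these compounds go, how far compound 4 lies past its limit stays open. Also open, from the compounds shown here alone, is whether the weakening is specific to nitro: an amine or a methoxy group at this place would bear on that.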